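A few compounds are considered here, and "the series" means these few. Any claim that something is new, unique, unknown or untested is made for them only; others in the source may bear on it.

Of the compounds shown here, three have been measured in a functional assay on the whole organism (stomach) for inhibition, with Rattus norvegicus as the target, at a dose of 100 mg/kg by the intraduodenal route (on this read-out lower numbers stand for less inhibition and higher numbers for more inhibition at the one dose given (going by the name of the read-out)), and a fourth awaits measurement. Compound 1 `N=C(S)CCCn1nc(-c2ccccc2)ccc1=O` gives 75.6% in this assay. Compound 2 `N=C(S)CCCCCCn1nc(-c2ccccc2)ccc1=O` gives 33.9% in this assay. The change that separates them is a group of 6 heavy atoms (4 carbon, 1 nitrogen, 1 sulfur; no ring) in place of a group of 3 heavy atoms (1 carbon, 1 nitrogen, 1 sulfur; no ring), on a saturated chain carbon, three bonds along the chain from an aromatic nitrogen, and the step it made was a number 41.7 percentage points lower from compound 1 to compound 2 (beyond the scatter).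

Compound 3 `N=C(S)CCN1N=C(c2ccccc2)CCC1=O` carries a different core; the difference between the core of compound 3 and the core of compound 1 is not broken down here. In this assay compound 3 gives 38.2%, which sits within the usual scatter of the value of compound 2 and well under that of compound 1.

Compound 4 `N=C(S)CCCCCN1N=C(c2ccccc2)CCC1=O` is to be measured in this assay. It differs from compound 3 by a group of 6 heavy atoms (4 carbon, 1 nitrogen, 1 sulfur; no ring) in place of a group of 3 heavy atoms (1 carbon, 1 nitrogen, 1 sulfur; no ring), on a saturated chain carbon, two bonds along the chain from an amide-type nitrogen in a ring. Going by the values given here, this is the same kind of change as the one from compound 1 to compound 2, though not the same: in compound 1 the replaced group sits three bonds along the chain from an aromatic nitrogen, whereas in compound 3 it sits two bonds along the chain from an amide-type nitrogen in a ring. Set beside the earlier step of a number 41.7 percentage points lower from compound 1 to compound 2 (beyond the scatter), the step expected here is a number 23.2 percentage points lower from compound 3 to compound 4 (beyond the scatter), smaller in size, which rests on compound 3 already giving the low value 38.2%, leaving less room to fall. For compound 4 the expected result in this assay is 15%, with a range from 0% to 38%.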

Compound 4, a percentage reported as inhibition, in the whole organism at one dose (the size of the read-out at that dose, not a potency): 48.5%
Compound 4: middle estimate off by 33.5 percentage points, on the low side, and the stated range ends below it.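

Carried onto the core of compound 3, the change did not repeat what it had done on the core of compound 1: in this assay, the group of 6 heavy atoms in place of the group of 3 heavy atoms gave a number 10.3 percentage points higher from compound 3 to compound 4 (beyond the scatter). Set beside a number 41.7 percentage points lower from compound 1 to compound 2 (beyond the scatter), this shows that in these two pairs the outcome of the change is tied to the core and cannot simply be transferred from one to the other: the same change on two cores in this assay, a number 41.7 percentage points lower (beyond the scatter) from compound 1 to compound 2 and a number 10.3 percentage points higher (beyond the scatter) from compound 3 to compound 4, 52 percentage points apart, beyond the scatter of two such steps It does not show which feature of the core decides the direction, since each core is represented by a single pair at one dose, and the place of the change also differs, three bonds along the chain from an aromatic nitrogen in one pair and two bonds along the chain from an amide-type nitrogen in a ring in the other.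

The compounds shown leave open how the read-out behaves with a shorter or a longer chain on either core, so no trend with chain length can be drawn from them. Also open, going by these compounds, is what an amine or a carboxylic acid would do in place of the group that the four compounds share.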